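The compounds below may be only part of what the source reports. "The series", "measured", "known", "first", "only" and "open" are said of these compounds alone.

Of the compounds shown here, three that share one core have been tested in a functional assay on A549 cells (Homo sapiens) for cytotoxicity; a lower number here means that less compound is needed, a higher number that more compound is needed for the effect. Compound 1 `COC1=C(C)C(=O)/C(=C(O)/C=C/c2ccc(Br)cc2)C(=O)C1(C)C` gives 1.4 ug/mL, compound 2 `COC1=C(C)C(=O)/C(=C(O)/C=C/c2ccc(O)cc2)C(=O)C1(C)C` gives 3.1 ug/mL, and compound 3 `COC1=C(C)C(=O)/C(=C(O)/C=C/c2ccccc2C)C(=O)C1(C)C` gives 4.6 ug/mL. Compound 2 thus stands second highest of the three numbers: a 2.2-fold higher number from compound 1 to compound 2 (0.35 log units; beyond the scatter), while a 1.5-fold higher number from compound 2 to compound 3 (0.17 log units; within the scatter).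

The next compound is compound 4 `C=Cc1ccccc1/C=C/C(O)=C1/C(=O)C(C)=C(OC)C(C)(C)C1=O`, which differs from compound 2 in one place: 2-vinylphenyl in place of 4-hydroxyphenyl on a double-bonded chain carbon bound to a double-bonded chain carbon. The step that bears most directly on this change is the one already measured from the 4-hydroxyphenyl to a 2-methylphenyl, a 1.5-fold higher number from compound 2 to compound 3 (0.17 log units; within the scatter), since 2-vinylphenyl and 2-methylphenyl are close relatives; the step of a 3.3-fold higher number from compound 1 to compound 3 (0.52 log units; beyond the scatter) also points toward a somewhat higher number for such aryl groups. A small rise, or no step beyond the scatter, is therefore expected in this assay. Compound 4 is estimated at 4.5 ug/mL, within a range of 2 ug/mL to 10 ug/mL, which corresponds to an expected step of a 1.5-fold higher number from compound 2 to compound 4 (0.16 log units; within the scatter).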

Compound 4, concentration for half-maximal effect: 2.2 ug/mL
Compound 4: the middle estimate sits 2.0-fold (0.31 log units) above what was measured; measured number inside the range.
By their numbers in this assay, from the lowest: compounds 1, 4, 2 and 3 (each within the scatter of the next, the first and the last beyond it).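

Swapping the methyl on the aromatic carbon for vinyl gives a step beyond the scatter (a 2.1-fold lower number from compound 3 to compound 4 (0.32 log units; beyond the scatter)), so even closely related groups here need not give the same number in this assay. The 2-vinylphenyl group has no hydrogen-bond donor or acceptor, yet its steps from 4-hydroxyphenyl (a 1.4-fold lower number from compound 2 to compound 4 (0.15 log units; within the scatter)) and 4-bromophenyl (a 1.6-fold higher number from compound 1 to compound 4 (0.20 log units; within the scatter)) both stay within the scatter. No measurement shown explains these steps. Still open, from the compounds shown here alone, is how an amine or a carboxylic acid on the phenyl ring, or a longer chain in place of vinyl, would change the number.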